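A few compounds are considered here, and "the series" means these few. Any claim that something is new, unique, unknown or untested is made for them only; others in the source may bear on it.

Measured in a functional assay on LOX IMVI cells (Homo sapiens) for cytotoxicity, read by resazurin assay, with a stated time of 72 h; on this read-out higher numbers stand for weaker inhibition and lower numbers for stronger inhibition:
compound 1 `COc1cc(/C=C/C(=O)OCCCCOc2no[n+]([O-])c2S(=O)(=O)c2ccccc2)ccc1O` gives 440 nM.
compound 2 `COc1cc(/C=C/C(=O)OC(C)C)ccc1O` gives > 50000 nM, which is a limit of the assay and not a number.
compound 3 `O=C(/C=C/c1ccc(O)c(O)c1)OCc1c(-c2ccccc2)no[n+]1[O-]` gives 13300 nM.

Of the two numbers shown, compound 3 carries the higher one, the weaker inhibition. Its nearest neighbour is compound 1, which sits far lower, beyond the scatter, and the two differ at several places at once, so no single step can be read between them. The third entry is only (the limit of > 50000 nM in this assay, at which 1 of the 3 values shown sits), belonging to compound 2.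

Compound 4 `COc1cc(/C=C/C(=O)OCc2c(-c3ccccc3)no[n+]2[O-])ccc1O` is not yet measured. It differs from compound 3 by methyl in place of hydrogen on an oxygen on an aromatic ring: the catechol side of compound 3 becomes the 4-hydroxy-3-methoxyphenyl side already present in compound 1 and compound 2, while the ester portion of compound 3 is kept. Among the measured compounds shown here, no measured pair in this set differs at a single place, so the size of such a step has not been seen. In this assay the step from compound 3 to compound 4 is expected to stay near the scatter, leaning, if anywhere, toward weaker inhibition; the estimate places a 1.2-fold higher number from compound 3 to compound 4 (0.08 log units; within the scatter) as a small rise. Compound 4 is expected to give 16000 nM, within a range from 5000 nM to 45000 nM.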

Compound 4, half-maximal inhibitory concentration: 13800 nM
For compound 4 the middle estimate is 1.2-fold (0.06 log units) above the measured one; low and high end bracket the measured number.
By their numbers in this assay, from the lowest: compound 1; then compounds 3 and 4 (each within the scatter of the next). At a limit, above all of these: compound 2.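

In this assay, among the compounds shown here, the only single-place step is a 1.0-fold higher number from compound 3 to compound 4 (0.02 log units; within the scatter), with methyl in place of hydrogen on an oxygen on an aromatic ring. For the compounds shown here, with the ester portion of compound 3 kept, this pair gives a first reading at this oxygen: the 3,4-dihydroxyphenyl and 4-hydroxy-3-methoxyphenyl sides are not told apart by this read-out, which holds for this one ester portion only. Nothing measured here gives a reason for this result.

All other pairs differ at several places at once, so their steps cannot be read, and the ester portion, where the series' values lie furthest apart, has no single-place step of its own. Open questions are whether the same step from the 3,4-dihydroxyphenyl to the 4-hydroxy-3-methoxyphenyl side would also stay within the scatter on the ester portion of compound 1, and whether a longer chain on this oxygen, such as ethyl or butyl, or an acetyl group there would do the same.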